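This account rests on a few compounds, and the source may have more. Where it says the series, first, only, none or still open, it means among the compounds named here.

Going by the values given here, compound 2 `COc1cccc2c1c(NS(=O)(=O)c1ccc(Cl)s1)nn2Cc1cccc(CNC(=O)C2COC2)c1` is one of two compounds measured in an assay on isolated protein (blood) for antagonist activity at C-C chemokine receptor type 4 (Homo sapiens), read by flow cytometry, with a stated time of 30 min; on this read-out higher numbers stand for weaker binding and lower numbers for tighter binding. In this assay compound 2 gives 1000 nM. The other measured compound, compound 1 `CC(=O)NCc1cccc(Cn2nc(NS(=O)(=O)c3ccc(Cl)s3)c3c(O)cccc32)c1`, gives 794 nM in this assay, and the two values lie within the scatter of each other, so compound 2 does not stand apart from compound 1 on the numbers shown.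

Compound 3 `COc1cccc2c1c(NS(=O)(=O)c1ccc(Cl)s1)nn2Cc1cccc(CNC(=O)C(C)(C)N)c1` has not yet been measured. It differs from compound 2 in one place: 1-amino-1-methylethyl in place of oxetan-3-yl on a carbonyl carbon. Among the compounds with values here, nothing among the measured pairs tells how such a change plays out, as no two measured compounds differ in a single place, so there is no step to lean on. The amide itself and the rest of the molecule are kept as they are in compound 2.

In the absence of any measured step of this kind, the step from compound 2 to compound 3 in this assay is expected to be small, a 1.3-fold lower number from compound 2 to compound 3 (0.10 log units; within the scatter), with no direction that can be called beyond the scatter. Compound 3 is therefore estimated to give about 800 nM in this assay, with a range from 300 nM to 2500 nM.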

Compound 3, dissociation constant: 141 nM
Compound 3: middle estimate off by 5.7-fold (0.75 log units), on the high side, outside the stated range (below it).
By their numbers in this assay, from the lowest: compound 3; then compounds 1 and 2 (each within the scatter of the next).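

Going by these compounds alone, the change on the carbonyl carbon gives the first single-place step, and it is not neutral: in this assay it is a 7.1-fold lower number from compound 2 to compound 3 (0.85 log units; beyond the scatter) and so lies beyond the scatter. Both oxetan-3-yl and 1-amino-1-methylethyl hold 4 heavy atoms, so at this position the heavy-atom count alone does not settle the number; the groups differ in that the entering one has nitrogen in place of oxygen, no ring and a hydrogen-bond donor. Nothing measured here says which of these differences matters or why the number falls.

The compounds shown leave open whether the amine alone carries the step or the two methyl groups share in it, which an aminomethyl group or a tert-butyl group on the same carbonyl carbon would separate. They also leave open whether the step would hold on the core of compound 1, and how a carboxylic acid or a longer chain ending in an amine would read at this position.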